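The source may hold more compounds than are shown below. What is called first, only, known or untested is meant among the compounds shown, and "the series" means these compounds.

Three compounds that share one core, each carrying a cyclopropyl group, were tested in an ADME assay on cells for inhibition of cytochrome P450 11B1, mitochondrial (Homo sapiens), read by HPLC, with a stated time of 60 min; a higher number here means a weaker inhibitor, a lower number a stronger inhibitor. Compound 1 `Fc1ccc2nc(-c3cncnc3)n(C3CC3)c2c1` gives 5380 nM. Compound 2 `Fc1ccc2nc(-c3cccnn3)n(C3CC3)c2c1` reaches only the limit of this assay, > 10000 nM. Compound 3 `Fc1cc2nc(-c3cncnc3)n(C3CC3)c2cc1F` gives 2270 nM. Among the numbers shown, compound 3 stands lowest, with compound 1 nearest, because a 2.4-fold lower number from compound 1 to compound 3 (0.37 log units; beyond the scatter). The other step, an at least 1.8-fold higher number from compound 1 to compound 2 (0.26 log units; that floor lies within the scatter), exchanges pyrimidin-5-yl for pyridazin-3-yl. Compound 2 sits at the limit of > 10000 nM in this assay, at which 1 of the 3 values shown sits.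

Compound 4 `CC(C)c1ncncc1-c1nc2cc(F)c(F)cc2n1C1CC1` differs from compound 3 by isopropyl in place of hydrogen on an aromatic carbon. Neither measured step resembles this change: the step from compound 1 to compound 3 adds a fluoro, and the step from compound 1 to compound 2 replaces one six-membered ring with another. No step shown, then, bears directly on adding an isopropyl group of 3 heavy atoms to the ring with 2 nitrogen, and the two steps that are shown were both modest or within the scatter. For that reason no shift beyond the scatter is expected, and the step is estimated as a 1.1-fold higher number from compound 3 to compound 4 (0.04 log units; within the scatter). Compound 4 is therefore expected to give 2500 nM in this assay, with a range from 700 nM to 9000 nM that is wide for want of any closely related step.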

Compound 4, half-maximal inhibitory concentration: 1910 nM
Beside the measured number, compound 4's estimate is 1.3-fold (0.12 log units) above it, and the stated range covers the measured number.
By their numbers in this assay, from the lowest: compounds 4 and 3 (each within the scatter of the next); then compound 1. At a limit, above all of these: compound 2.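

In this assay, the new step is a 1.2-fold lower number from compound 3 to compound 4 (0.07 log units; within the scatter), so the two numbers cannot be told apart. Going by these compounds alone, this is the first look at a change on this carbon of the six-membered aromatic ring with 2 nitrogen, next to the ring nitrogen and ortho to a large group, since compounds 1 and 3 both carry hydrogen there. It shows that an isopropyl group, with its 3 heavy atoms and no ring, can stand at this place with no readable loss in this assay, which neither earlier step could show. No measurement given here bears on why this step is so small.

What one group at one place cannot show is how far this allowance extends: a methyl, a longer chain, an amine or a carboxylic acid on the same carbon could give quite a different number. On these data alone, it also stays open whether isopropyl would give the same result on compound 1, which has one fluoro on the shared core where compound 3 has two.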